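The source may report more compounds than this note shows. Statements on the series, on what has been measured and on what is new or still open speak of the compounds shown alone.

Measured so far in a physicochemical assay for solubility, read by HPLC, in phosphate buffer, measured as kinetic solubility, with a stated time of 1 h, at pH 7.4, tested at 250 uM; a higher number here means a more soluble compound, a lower number a less soluble compound:
Compound 1 `O=C(NCCCCc1ccccc1)n1cc(-c2ccc(F)cc2)oc1=O`: < 1000 nM, a limit of the assay and not a number
Compound 2 `CN1CCC(c2cc(F)ccc2-c2cn(C(=O)NCCCCc3ccccc3)c(=O)o2)CC1`: 60000 nM

For the measured compounds named here, compound 2, at 60000 nM, holds the only actual number in this assay. Going by the values given here, the one measured step is an at least 60-fold higher number from compound 1 to compound 2 (1.77 log units; beyond the scatter), and it comes with 1-methylpiperidin-4-yl in place of hydrogen on an aromatic carbon. Compound 3 `CCCCCNC(=O)n1cc(-c2ccc(F)cc2C2CCN(C)CC2)oc1=O` keeps that group and changes the chain instead: methyl in place of phenyl on a saturated chain carbon, four bonds along the chain from an amide-type nitrogen. In words, this is methyl in place of phenyl on a saturated chain carbon, four bonds along the chain from an amide-type nitrogen. Cut one bond further out, it reads 3-phenylpropyl to butyl. Among the compounds with values here, the large step bears on this change only loosely, since it lies at another place and no measured step touches the chain. It shows only that the read-out can move far among these compounds. Starting from compound 2 at 60000 nM, a modest upward step is expected rather than a large one, and the direction is held with little confidence. The estimated change is a 1.8-fold higher number from compound 2 to compound 3 (0.26 log units; within the scatter). For compound 3 the expected value is 110000 nM, with an estimated range of 45000 nM to 250000 nM.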

Compound 3, solubility: > 250000 nM
Compound 3: no number, only a limit; the forecaster's own chance of this, stated with the estimate: 10%; middle value at least 2.2-fold (0.35 log units) away from the limit.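

In this assay, the chain now has a measured step of its own: an at least 4.1-fold higher number from compound 2 to compound 3 (0.61 log units; beyond the scatter), with methyl in place of phenyl on a saturated chain carbon, four bonds along the chain from an amide-type nitrogen. Compound 3 gives > 250000 nM, which is a limit of the assay and not a number, so the step fixes only a minimum size and not the size itself. The earlier step showed movement only with a change on an aromatic carbon, whereas this one shows the read-out moving beyond the scatter with a change on the chain while the 1-methylpiperidin-4-yl group stays in place, and it ends at the upper limit of the read-out: the limit of > 250000 nM in this assay, at which 1 of the 3 values shown sits.

The compounds shown leave open whether the gain comes from the loss of the phenyl ring itself or from the change in the chain as a whole, which a cyclohexyl group or a longer alkyl chain at the same place could separate. They also leave open whether the same exchange of 3-phenylpropyl for butyl would move the read-out on a core carrying hydrogen in place of the 1-methylpiperidin-4-yl group.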